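Extending an Aryl Ether Chain in a Weakly Active Series

The source may hold more compounds than are shown below. What is called first, only, known or untested is meant among the compounds shown, and "the series" means these compounds.

Compound 1 `O=C(NNc1nncc2ccccc12)C1CC1c1ccc(OC(F)(F)F)cc1`: 29000 nM
Compound 2 `CCOc1ccc(C2CC2C(=O)NNc2nncc3ccccc23)cc1`: "not determined" (no result reported)
Compound 3 `CC(C)=CCOc1ccc(C2CC2C(=O)NNc2nncc3ccccc23)cc1`: to be measured

Compound 1 was tested in a functional assay on SK-MEL cells (Homo sapiens) for inhibition, read by MTT assay, with a stated time of 72 h (on this read-out higher numbers stand for weaker inhibition and lower numbers for stronger inhibition), and gives 29000 nM, a weak result. Compound 2 carries an ethoxy group on its aromatic ring where compound 1 carries a trifluoromethoxy group, but in this assay compound 2 is recorded as "not determined" (no result reported), so it has no place on the scale; the only measured point here is compound 1. Compound 3 differs from compound 2 by 2-methylprop-1-en-1-yl in place of methyl on a saturated chain carbon bound to an oxygen on an aromatic ring. Among the measured compounds shown here, no measured pair in this set shows what such a change does, so no step size can be read off, and its direction is open. For the measured compounds named here, since the one measured compound, compound 1, is weak at 29000 nM, compound 3 is expected to land in a similarly weak region, with a wide spread. Compound 3 is estimated at 20000 nM, between 4000 nM and 80000 nM.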

Compound 3, half-maximal inhibitory concentration: 67000 nM
Beside the measured number, compound 3's estimate is 3.4-fold (0.53 log units) below it; low and high end bracket the measured number.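

In this assay, putting 3-methylbut-2-en-1-yl in place of trifluoromethyl on the oxygen on the aromatic ring gives a 2.3-fold higher number from compound 1 to compound 3 (0.36 log units; beyond the scatter), a modest shift towards weaker inhibition. Among the compounds shown here, this is the first measured sign of what a change at this oxygen does: of these two compounds, the one with the longer, branched chain with a double bond is the weaker, and neither comes close to strong inhibition. No available evidence explains the shift.

Compound 2 has no number, so the ethoxy group cannot serve as a reference and the step from it to compound 3 cannot be read. Going by these compounds, it remains open whether the double bond, the branching or the chain length matters, and whether a saturated butyl chain or a chain carrying an amine would change the result.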